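The source may report more compounds than this note shows. Statements on the series, on what has been measured and on what is new or still open speak of the compounds shown alone.

Compound 1 `CC(C)[C@@H]1CC[C@@H](C)C[C@@]12N(C)C(=O)[C@@H]1[C@H]3C(=O)NC(=O)[C@H]3ON12` gives 42.6%.
Compound 2 `CC(C)[C@@H]1CC[C@@H](C)C[C@@]12N(C)C(=O)[C@@H]1[C@H]3C(=O)N(C)C(=O)[C@H]3ON12` gives 41.5%.
Compound 3 `Cc1ccc(N2C(=O)[C@H]3[C@H](ON4[C@@H]3C(=O)N(C)[C@@]43C[C@H](C)CC[C@H]3C(C)C)C2=O)c(C)c1` gives 69%.

These three numbers come from a functional assay, read by spectrophotometry, with a stated time of 2 h, tested at 1 mg/mL; on this read-out lower numbers stand for a weaker effect and higher numbers for a stronger effect at the one concentration tested. Compound 3 stands highest of the three, with its nearest neighbour compound 1 sitting a number 26.4 percentage points higher from compound 1 to compound 3 (beyond the scatter) and compound 2 sitting a number 27.5 percentage points higher from compound 2 to compound 3 (beyond the scatter) below it, both beyond the scatter. The untested compound 4 `CC(C)[C@@H]1CC[C@@H](C)C[C@@]12N(C)C(=O)[C@@H]1[C@H]3C(=O)N(c4ccc5ccccc5c4)C(=O)[C@H]3ON12` differs from compound 3 in one place: naphthalen-2-yl in place of 2,4-dimethylphenyl on an amide-type nitrogen in a ring. Within the data shown here, no measured step swaps one aromatic group for another; the two steps that bear on this position show only that an aromatic ring on that nitrogen raised the number modestly over hydrogen or methyl. Since compound 4 keeps an aromatic ring there, the expected step of a number 3 percentage points lower from compound 3 to compound 4 (within the scatter) is small or none beyond the scatter. Compound 4 is therefore estimated at 66%, expected between 46% and 86%.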

Compound 4, a percentage reported as activity, at one concentration (the size of the read-out at that concentration, not a potency): 33.2%
The estimate for compound 4 lay 32.8 percentage points above the measured number, outside the stated range (below it).
By their numbers in this assay, from the lowest: compounds 4, 2 and 1 (each within the scatter of the next); then compound 3.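

In this assay an aromatic ring on this amide-type nitrogen does not by itself raise the number: swapping 2,4-dimethylphenyl for naphthalen-2-yl loses the earlier gain (a number 35.8 percentage points lower from compound 3 to compound 4 (beyond the scatter)). Naphthalen-2-yl shows no gain over methyl (a number 8.3 percentage points lower from compound 2 to compound 4 (within the scatter)) or over hydrogen (a number 9.4 percentage points lower from compound 1 to compound 4 (within the scatter)), so among these compounds the gain belongs to 2,4-dimethylphenyl alone, not to aromatic groups in general. No measurement here accounts for the difference between these two aromatic groups.

On these data alone, it remains open how a plain phenyl ring would behave on this nitrogen. The same holds for a phenyl ring carrying a single methyl group or a methoxy group.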